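A few compounds are considered here, and "the series" means these few. Any claim that something is new, unique, unknown or untested is made for them only; others in the source may bear on it.

Going by the values given here, in a functional assay on A549 cells (Homo sapiens) for antiproliferative activity, read by MTT assay, with a stated time of 48 h (a higher number here means a weaker inhibitor of growth, a lower number a stronger inhibitor of growth), compound 2 `COC(=O)N1N=C(c2cccc(Cl)c2)CC1c1cc(OC)c(OC)c(OC)c1` gives 340 nM and holds the lower of the two numbers so far. Compound 1 `COC(=O)N1N=C(c2ccc(OC)cc2)CC1c1cc(OC)c(OC)c(OC)c1` gives 3400 nM in this assay as well. Compound 3 `COC(=O)N1N=C(c2ccc(O)cc2)CC1c1cc(OC)c(OC)c(OC)c1` is still unmeasured and differs from compound 2 in one place, with 4-hydroxyphenyl in place of 3-chlorophenyl on a carbon with a double bond to nitrogen. Among the compounds with values here, only one measured step touches that place: a 10-fold lower number from compound 1 to compound 2 (1.00 log units; beyond the scatter) when 3-chlorophenyl replaces 4-methoxyphenyl. Within the data shown here, the new 4-hydroxyphenyl looks more like the 4-methoxyphenyl of compound 1 at 3400 nM than like the group it replaces, although no compound with a free hydroxy group has been measured yet. A move back towards a higher number in this assay is expected, similar to that earlier step or somewhat smaller. The estimated step is a 5.9-fold higher number from compound 2 to compound 3 (0.77 log units; beyond the scatter) and carries real uncertainty. Compound 3 is expected at 2000 nM with 600 nM to 7000 nM as the estimated range.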

Compound 3, concentration for 50% growth inhibition: 8570 nM
For compound 3 the middle estimate is 4.3-fold (0.63 log units) below the measured one; the whole stated range lies below it.
By their numbers in this assay, from the lowest: compound 2; then compound 1; then compound 3.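

In this assay, the swap at this place gives a 25-fold higher number from compound 2 to compound 3 (1.40 log units; beyond the scatter), which makes the gap opened by 3-chlorophenyl larger than the earlier 4-methoxyphenyl comparison showed. Removing only the methyl from the oxygen gives a 2.5-fold higher number from compound 1 to compound 3 (0.40 log units; beyond the scatter), so this position responds even to that small edit, and the free hydroxy group sits further from compound 2 than the methoxy group does. No measurement available here explains either difference.

Compound 2 differs from the two oxygen-bearing compounds in both the atom on the phenyl ring and where it sits, so the compounds shown cannot separate these two changes; 4-chlorophenyl and 3-hydroxyphenyl would pull them apart. As far as these compounds go, how an amine on this phenyl ring would compare also remains open.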